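The compounds below may be only part of what the source reports. "The series", "measured", "known", "first", "only" and "open" are said of these compounds alone.

Measured so far: compound 1 `COc1ccc(C(=O)OC(CCN(C)C)c2ccc(Cl)cc2)cc1` with 2190 nM in an assay on NIH3T3 cells with Urotensin-2 receptor (Homo sapiens) as the target; a higher number here means that more compound is needed for the effect, a lower number that less compound is needed; compound 2 `Cc1c(Cl)cccc1C(=O)OC(CCN(C)C)c1ccc(Cl)cc1` with 1120 nM in this assay.

Compound 2 stands at the lower of the two numbers, but the step of a 2.0-fold lower number from compound 1 to compound 2 (0.29 log units; within the scatter) is within the scatter. Compound 3 `Cc1ccccc1NC(=O)OC(CCN(C)C)c1ccc(Cl)cc1` differs from compound 2 by (2-methylphenyl)amino in place of 3-chloro-2-methylphenyl on a carbonyl carbon. Among the measured compounds shown here, no measured step exchanges the aryl group on that carbonyl carbon for an arylamino group; the only step available, a 2.0-fold lower number from compound 1 to compound 2 (0.29 log units; within the scatter), concerns substituents on the aryl group and stays within the scatter. For compound 3 no step beyond the scatter is therefore expected, a 1.2-fold higher number from compound 2 to compound 3 (0.06 log units; within the scatter). The estimate for compound 3 is 1300 nM, with a range from 400 nM to 4500 nM.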

Compound 3, half-maximal effective concentration: 3890 nM
Compound 3: the middle estimate sits 3.0-fold (0.48 log units) below what was measured; the measured number falls inside the stated range.
By their numbers in this assay, from the lowest: compounds 2, 1 and 3 (each within the scatter of the next, the first and the last beyond it).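

Among the compounds shown here, with the arylamino group on this carbonyl carbon in this assay, (2-methylphenyl)amino in place of 3-chloro-2-methylphenyl gives a 3.5-fold higher number from compound 2 to compound 3 (0.54 log units; beyond the scatter) and is the first change to pass the scatter, if only modestly. The same group in place of 4-methoxyphenyl gives a 1.8-fold higher number from compound 1 to compound 3 (0.25 log units; within the scatter) and so stays inside it, which means the exchange does not read alike against both aryl groups. No evidence on the cause is at hand. From the compounds shown here alone, the nitrogen and the loss of chlorine enter together in the step from compound 2, so their shares stay open. A (3-chloro-2-methylphenyl)amino group on the same carbonyl carbon would separate them.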